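Triazole in place of diethylamino on the shared core

A few compounds are considered here, and "the series" means these few. Any claim that something is new, unique, unknown or untested is made for them only; others in the source may bear on it.

Compound 2 `CCN(CC)C/C1=C/C[C@](C)(CCC=C(C)C)/C=C/[C@@H](OC(=O)C=C(C)C)[C@](C)(O)/C=C/C1=O` gives the lowest of the two measured numbers in a functional assay on SMMC-7721 cells (Homo sapiens) for antiproliferative activity, read by MTT assay, with a stated time of 48 h (on this read-out lower numbers stand for stronger inhibition and higher numbers for weaker inhibition), at 570 nM. Compound 1 `CC(=O)OC/C1=C/C[C@](C)(CCC=C(C)C)/C=C/[C@@H](OC(=O)C=C(C)C)[C@](C)(OC(C)=O)/C=C/C1=O` gives 4130 nM in this assay, a gap from compound 2 that lies beyond the scatter. Compound 3 `CC(C)=CCC[C@]1(C)/C=C/[C@@H](OC(=O)C=C(C)C)[C@](C)(O)CCC(=O)/C(CO)=C\C1` reaches only a limit in this assay, reported as > 40000 nM, which is the limit of > 40000 nM in this assay, at which 1 of the 3 values shown sits. Compound 4 `CC(C)=CCC[C@]1(C)/C=C/[C@@H](OC(=O)C=C(C)C)[C@](C)(O)/C=C/C(=O)/C(Cn2cc(CO)nn2)=C\C1` is not yet measured and differs from compound 2 in one place: 4-(hydroxymethyl)-1H-1,2,3-triazol-1-yl in place of diethylamino on a saturated chain carbon bound to a double-bonded ring carbon. For the measured compounds named here, no step between measured compounds covers this change. The step of a 3.5-fold higher number from compound 2 to compound 4 (0.55 log units; beyond the scatter) is expected to be a moderate weakening beyond the scatter, with the direction held uncertain. For compound 4 the estimate in this assay is 2000 nM, within 500 nM to 10000 nM.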

Compound 4, half-maximal inhibitory concentration: 3560 nM
Estimate against measurement, compound 4: 1.8-fold (0.25 log units) below; the measured number falls inside the stated range.
By their numbers in this assay, from the lowest: compound 2; then compounds 4 and 1 (each within the scatter of the next). At a limit, above all of these: compound 3.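

For the compounds shown here, this is the first single-place change read at this position: on a saturated chain carbon bound to a double-bonded ring carbon, 4-(hydroxymethyl)-1H-1,2,3-triazol-1-yl in place of diethylamino gives a 6.2-fold higher number from compound 2 to compound 4 (0.80 log units; beyond the scatter) in this assay. The position therefore responds to the group it carries, although compound 4 still gives a measured number, 3560 nM. No measured property bears on this step.

On these data alone, whether the weakening goes with the triazole ring itself or with its hydroxymethyl stays open. Also open, as far as these compounds go, is how a morpholine, a pyrrolidine or a triazole carrying a carboxylic acid would read here.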